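Removing a Ring Fluorine from a Sulfonamide Side Chain

The source may report more compounds than this note shows. Statements on the series, on what has been measured and on what is new or still open speak of the compounds shown alone.

Three compounds share one core and differ only in the sulfonamide-bearing side chain. Compound 1 `O=S(=O)(NCCCNc1nccc(-c2c(-c3cccc(F)c3)nc3sccn23)n1)c1ccc(Br)cc1` carries a bromo group on the sulfonyl ring; in a functional assay on SK-MEL-28 cells (Homo sapiens) for cytotoxicity, read by MTT assay (on this read-out higher numbers stand for weaker inhibition and lower numbers for stronger inhibition), compound 1 gives 9400 nM. Compound 2 `Cc1ccc(S(=O)(=O)NCCCNc2nccc(-c3c(-c4cccc(F)c4)nc4sccn34)n2)cc1` has methyl in place of bromo, and in this assay compound 2 gives 9500 nM; the step of a 1.0-fold higher number from compound 1 to compound 2 (0.00 log units; within the scatter) shows that swapping these two groups on the sulfonyl ring changed nothing beyond the scatter. Compound 3 `O=S(=O)(NCCNc1nccc(-c2c(-c3cccc(F)c3)nc3sccn23)n1)c1cccc(F)c1` shortens the chain and moves to a fluoro-bearing ring, and in this assay compound 3 gives 18300 nM. Its number lies within the scatter of both others, as a 1.9-fold higher number from compound 1 to compound 3 (0.29 log units; within the scatter) and a 1.9-fold higher number from compound 2 to compound 3 (0.28 log units; within the scatter) show.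

Compound 4 `O=S(=O)(NCCNc1nccc(-c2c(-c3cccc(F)c3)nc3sccn23)n1)c1ccccc1` differs from compound 3 in one place: hydrogen in place of fluoro on an aromatic carbon, so that 3-fluorophenyl becomes phenyl. For the measured compounds named here, the only measured step touching this same ring is a 1.0-fold higher number from compound 1 to compound 2 (0.00 log units; within the scatter), which stayed within the scatter, and no measured step removes a fluoro. The expected step of a 1.0-fold lower number from compound 3 to compound 4 (0.01 log units; within the scatter) is therefore none beyond the scatter. Compound 4 is estimated at 18000 nM, with a range from 8000 nM to 40000 nM.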

Compound 4, half-maximal inhibitory concentration: 19000 nM
The estimate for compound 4 lay 1.1-fold (0.02 log units) below the measured number, and the stated range covers the measured number.
By their numbers in this assay, from the lowest: compounds 1, 2, 3 and 4 (each within the scatter of the next, the first and the last beyond it).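

In this assay, for the compounds shown here, taking the fluoro off the 3-fluorophenyl ring to leave plain phenyl gives a 1.0-fold higher number from compound 3 to compound 4 (0.02 log units; within the scatter), which lies within the scatter, so this ring position tolerates the loss of its only substituent, something no earlier step tested. The earlier swap of bromo for methyl exchanged one group for another, whereas here a single heavy atom goes and only a hydrogen enters, and the read-out still does not respond. Going by these compounds alone, compound 4 also supplies the only step in the set that passes the scatter, a 2.0-fold higher number from compound 1 to compound 4 (0.31 log units; beyond the scatter) (a modest one), while its counterpart, a 2.0-fold higher number from compound 2 to compound 4 (0.30 log units; within the scatter), stays within the scatter, and both of these alter the side chain and the sulfonyl ring together, so neither can be credited to one part alone. No separate data bear on this result, so the flat response stays unexplained.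

The compounds shown leave open whether a different group at this ring position, such as an amine or a carboxylic acid, would move the number beyond the scatter. They also leave open how plain phenyl behaves on a longer chain, which would separate the effect of the chain from that of the ring.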